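Swapping the aryl amide for a pyridyl: toxicity outlook

The source may report more compounds than this note shows. Statements on the series, on what has been measured and on what is new or still open speak of the compounds shown alone.

Measured compounds in a toxicity assay on THP-1 cells (Homo sapiens) for inhibition; on this read-out lower numbers stand for higher toxicity in this test and higher numbers for lower toxicity in this test:
compound 1 `Cc1ccccc1C(=O)Nc1ncc(-c2ccccc2)n1C` gives > 100000 nM, which is a limit of the assay.
Compound 2 `COc1ccc(-c2cnc(NC(=O)c3ccccc3C)n2C)cc1` gives > 100000 nM, which is also a limit.
Compound 3 `COc1ccc2nc(NC(=O)c3ccc(F)cc3)n(C)c2c1` gives > 100000 nM, again a limit.

Compound 2 stands at the limit of this assay rather than at a number. Within the data shown here, the only step between measured compounds, a step that the two limits leave unreadable from compound 1 to compound 2, is the methoxy in place of hydrogen on an aromatic carbon, and its size is not readable, since the two ends are both limits. All three values sit at the same point: the limit of > 100000 nM in this assay, at which 3 of the 3 values shown sit.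

The unmeasured compound 4 `COc1ccc(-c2cnc(NC(=O)c3ccccn3)n2C)cc1` differs from compound 2 in one place: pyridin-2-yl in place of 2-methylphenyl on a carbonyl carbon. Among the measured compounds shown here, none of the measured steps touches the carbonyl carbon side of the molecule, so no measured step bears directly on this change. What the data do show is that every compound of this kind so far sits at the limit, compound 2 among them, because of the limit of > 100000 nM in this assay, at which 3 of the 3 values shown sit.

Compound 4 is therefore expected to show no readable step in this assay, with a step that the limit leaves unreadable from compound 2 to compound 4 as the estimated change. Compound 4 is estimated at 150000 nM, between 50000 nM and 400000 nM, most likely reported again as a limit.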

Compound 4, half-maximal cytotoxic concentration: > 100000 nM
Compound 4 was reported as a limit (the forecaster's own chance of this, stated with the estimate: 85%); the middle value lies beyond the limit too.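

Compound 2 and compound 4 are both reported as limits, so no size can be read for the step of pyridin-2-yl in place of 2-methylphenyl on a carbonyl carbon. The compounds shown leave open which change, if any, would bring a readable number in this assay, for all of them stop at one point: the limit of > 100000 nM in this assay, at which 4 of the 4 values shown sit.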